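This account rests on a few compounds, and the source may have more. Where it says the series, first, only, none or still open, it means among the compounds named here.

In a functional assay on MIA PaCa-2 cells (Homo sapiens) for cytotoxicity, read by MTT assay, with a stated time of 4 h (on this read-out lower numbers stand for stronger inhibition and higher numbers for weaker inhibition), compound 1 `COC1=CC(=O)c2c(COc3ccc(C#N)cc3)c(C)n(C)c2C1=O` gives 463 nM, compound 2 `COC1=CC(=O)c2c(COc3ccc(C(F)(F)F)cc3)c(C)n(C)c2C1=O` gives 496 nM and compound 3 `COC1=CC(=O)c2c(COc3ccc(F)cc3)c(C)n(C)c2C1=O` gives 905 nM. Compound 3 is not separated from the other two by any step beyond the scatter, and the remaining pair shows the same: a 1.1-fold higher number from compound 1 to compound 2 (0.03 log units; within the scatter).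

The next change leads to compound 4 `COC1=CC(=O)c2c(COc3cccnc3)c(C)n(C)c2C1=O`, with pyridin-3-yl in place of 4-fluorophenyl on an oxygen on a saturated carbon.

The measured steps bear on this only in part. Among the compounds with values here, they exchange a group on an aromatic carbon, and none of them replaces the carbon-only ring by a ring with a hetero atom, so the data hold no direct precedent. The closest guides are a 2.0-fold higher number from compound 1 to compound 3 (0.29 log units; within the scatter) and a 1.8-fold higher number from compound 2 to compound 3 (0.26 log units; within the scatter). From the compounds shown here alone, on those two small steps, no shift beyond the scatter is expected in this assay, and the direction stays open.

The expected change is a 1.2-fold lower number from compound 3 to compound 4 (0.08 log units; within the scatter). For compound 4 the estimate is 750 nM, with an expected range of 280 nM to 2000 nM.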

Compound 4, half-maximal inhibitory concentration: 2480 nM
For compound 4 the middle estimate is 3.3-fold (0.52 log units) below the measured one; the whole stated range lies below it.
By their numbers in this assay, from the lowest: compounds 1, 2 and 3 (each within the scatter of the next); then compound 4.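

In this assay, the exchanges among the substituents on the aromatic carbon all stayed within the scatter, whereas changing the ring itself on the oxygen on a saturated carbon gives a step beyond it: a 2.7-fold higher number from compound 3 to compound 4 (0.44 log units; beyond the scatter) with pyridin-3-yl in place of 4-fluorophenyl, and a 5.4-fold higher number from compound 1 to compound 4 (0.73 log units; beyond the scatter) with pyridin-3-yl in place of 4-cyanophenyl. The ring at this position therefore affects the read-out more than the three substituents compared so far, although both steps are modest and rest on compound 4 alone. Nothing available explains the weaker number for compound 4.

The compounds shown leave open whether the shift follows the ring nitrogen or the absence of a ring substituent in compound 4. An unsubstituted phenyl and a pyridin-3-yl carrying a fluoro or a nitrile would separate these two readings.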